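Dropping one methoxy from the dimethoxyphenyl ketone

A few compounds are considered here, and "the series" means these few. Any claim that something is new, unique, unknown or untested is made for them only; others in the source may bear on it.

Measured compounds:
compound 1, `COc1cc(-c2cc(/C=C/C(=O)c3ccc(N)cc3)[nH]n2)cc(OC)c1OC`, -97%
compound 2, `COc1ccc(C(=O)/C=C/c2cc(-c3cc(OC)c(OC)c(OC)c3)n[nH]2)cc1OC`, -75%

In a functional assay on BT-549 cells (Homo sapiens) for cytotoxicity, read by sulforhodamine B assay, with a stated time of 48 h, tested at 100 uM (on this read-out higher numbers stand for a weaker effect at the one concentration tested and lower numbers for a stronger effect), compound 1 gives -97%, and compound 2 gives -75%. Between them lies one change, 3,4-dimethoxyphenyl in place of 4-aminophenyl on a carbonyl carbon, and it moves the read-out by a number 22 percentage points higher from compound 1 to compound 2 (beyond the scatter). Compound 2 therefore stands at the higher of the two numbers, with compound 1 below it by a step beyond the scatter.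

Compound 3 is `COc1ccc(C(=O)/C=C/c2cc(-c3cc(OC)c(OC)c(OC)c3)n[nH]2)cc1`. It differs from compound 2 by hydrogen in place of methoxy on an aromatic carbon, on an aromatic carbon of a six-membered aromatic ring of carbon only, ortho to a methoxy group and meta to a large group; cut one bond further out the change reads 3,4-dimethoxyphenyl to 4-methoxyphenyl.

No measured step touches this position: the only step shown swaps the whole aryl group on the carbonyl carbon, not a single methoxy. So nothing in the numbers points in either direction, and the step of a number 5 percentage points higher from compound 2 to compound 3 (within the scatter) is expected to stay within the scatter. Compound 3 is estimated at -70%, in a range from -95% to -35%.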

Compound 3, a percentage reported as activity, at one concentration (the size of the read-out at that concentration, not a potency): -49%
Compound 3: middle estimate off by 21 percentage points, on the low side, within the range that was stated.
By their numbers in this assay, from the lowest: compound 1; then compound 2; then compound 3.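

In this assay, the loss of one methoxy is not a silent change: hydrogen in place of methoxy on an aromatic carbon, ortho to a methoxy group, gives a number 26 percentage points higher from compound 2 to compound 3 (beyond the scatter), so this single position on the ketone's aryl group affects the read-out on its own, which the earlier swap of the whole aryl group could not show. The second new step, methoxy in place of amino on an aromatic carbon, gives a number 48 percentage points higher from compound 1 to compound 3 (beyond the scatter), which separates the 4-aminophenyl and 4-methoxyphenyl ketones by a large margin and places the 3,4-dimethoxyphenyl ketone of compound 2 between them in this assay. Nothing available explains either step, and the numbers record only that they occur.

The three compounds leave open whether the effect belongs to the methoxy itself or to any group at that carbon, which a hydroxyl, a chlorine or an ethoxy there would begin to separate. They also leave open whether an amine at that same carbon, alongside the 4-methoxy, would bring the read-out back towards that of compound 1.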